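The compounds below may be only part of what the source reports. "The series", "measured", "known", "first", "only" and "open" are said of these compounds alone.

Measured in a functional assay on NALM-6 cells (Homo sapiens) for cytotoxicity, read by luminescence and CellTiter-Glo, with a stated time of 3 days; a higher number here means a weaker inhibitor, a lower number a stronger inhibitor:
Compound 1 `N#Cc1ccc(NC(=O)c2ccc3cccnc3c2O)c(F)c1`: 370 nM
Compound 2 `O=C(Nc1cccc(C(F)(F)F)c1)c1cc(F)ccc1O`: 1800 nM

Compound 1, at 370 nM, holds the lower of the two numbers, and the gap to compound 2, at 1800 nM, lies beyond the scatter. Compound 3 `N#Cc1ccc(NC(=O)c2ccc3cccnc3c2O)c(Cl)c1` departs from compound 1 in one place: chloro in place of fluoro on an aromatic carbon, with chloro in place of fluoro on an aromatic carbon, ortho to a large group and meta to a cyano group. Among the measured compounds shown here, the measured compounds offer no step of this kind to go by, so no change beyond the scatter is expected. The estimated step is a 1.2-fold lower number from compound 1 to compound 3 (0.09 log units; within the scatter). Compound 3 is expected at 300 nM, within an estimated range of 120 nM to 800 nM.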

Compound 3, half-maximal inhibitory concentration: 420 nM
For compound 3 the middle estimate is 1.4-fold (0.15 log units) below the measured one, within the range that was stated.
By their numbers in this assay, from the lowest: compounds 1 and 3 (each within the scatter of the next); then compound 2.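

In this assay the change of chloro in place of fluoro on an aromatic carbon, ortho to a large group and meta to a cyano group, gives a 1.1-fold higher number from compound 1 to compound 3 (0.06 log units; within the scatter) and thus offers the first read on this position: the two halogens cannot be told apart here. No measurement available bears on the reason for this result. On these data alone, whether this position would tolerate a methyl, a methoxy or an amine remains open. So does how the compound would respond to hydrogen there, with no halogen at all.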